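Acyl variation on the tertiary amide of the trimethoxyanilide series

The source may report more compounds than this note shows. Statements on the series, on what has been measured and on what is new or still open speak of the compounds shown alone.

Values below come from a functional assay on MGC-803 cells (Homo sapiens) for inhibition, read by MTT assay, with a stated time of 48 h; a lower number here means a stronger inhibitor, a higher number a weaker inhibitor.
Compound 1 `COc1ccc(CNc2cc(OC)c(OC)c(OC)c2)cc1C` gives 56800 nM.
Compound 2 `C=C(C)C(=O)N(Cc1ccc(OC)c(O)c1)c1cc(OC)c(OC)c(OC)c1` gives 390 nM.
Compound 3 `COc1ccc(CNc2cc(OC)c(OC)c(OC)c2)cc1F` gives 39700 nM.

Compound 2 stands at the lowest number of the three in this assay, and its gap to both compound 1 and compound 3 lies beyond the scatter, so it is the strongest inhibitor among the measured set. Going by the values given here, the one step between measured compounds that differ in a single place, a 1.4-fold lower number from compound 1 to compound 3 (0.16 log units; within the scatter), concerns an aromatic substituent on the benzylamine side of the shared core and says nothing about the acyl group.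

Compound 4 `CC/C=C/C(=O)N(Cc1ccc(OC)c(O)c1)c1cc(OC)c(OC)c(OC)c1` is not yet measured. It differs from compound 2 by but-1-en-1-yl in place of 1-methylethenyl on a carbonyl carbon. Among the compounds with values here, no measured step touches this position, so the expectation rests on the change itself: a small acyl group is exchanged for another small acyl group of similar kind, with the rest of compound 2 kept intact. A step within the scatter is therefore expected in this assay, with no direction to call from the data at hand; the estimated step is a 1.3-fold higher number from compound 2 to compound 4 (0.11 log units; within the scatter). Compound 4 is expected to give about 500 nM, within a range from 200 nM to 1500 nM.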

Compound 4, half-maximal inhibitory concentration: 58 nM
Estimate against measurement, compound 4: 8.6-fold (0.94 log units) above; measured number outside the range, below it.
By their numbers in this assay, from the lowest: compound 4; then compound 2; then compounds 3 and 1 (each within the scatter of the next).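

In this assay, going by these compounds alone, the acyl group of the tertiary amide turns out to be a sensitive position: but-1-en-1-yl in place of 1-methylethenyl on the carbonyl carbon gives a 6.7-fold lower number from compound 2 to compound 4 (0.83 log units; beyond the scatter), a step beyond the scatter, whereas the only earlier single-place step, on the aromatic substituent, was a 1.4-fold lower number from compound 1 to compound 3 (0.16 log units; within the scatter). The exchange is small by count, with 3 heavy atoms leaving and 4 entering, all carbon, with no ring and 1 double bond outside aromatic rings on each side, so a small change at this carbonyl carbon is enough to move the number beyond the scatter. This pair alters chain length and the branching of the alkene together, so it cannot show which of these carries the step, and nothing available here bears on the cause.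

Going by these compounds, it remains open whether the number keeps falling with a longer chain such as hex-1-en-1-yl, and whether the step survives in a saturated butyl group or an acyl group carrying an amine. Compound 2 differs from compound 1 and compound 3 in more than one place, so the share of the acyl group in those gaps also remains unresolved.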